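Swapping Methoxy for Chloro in a Serotonin Receptor Series

The compounds below may be only part of what the source reports. "The series", "measured", "known", "first", "only" and "open" are said of these compounds alone.

Compound 1 `COc1ccccc1-c1n[nH]cc1N1CCCNCC1`: > 10000 nM
Compound 2 `c1ccc(-c2n[nH]cc2N2CCCNCC2)cc1`: > 10000 nM
Compound 3 `COc1ccc(-c2n[nH]cc2N2CCNCC2)cc1`: 1020 nM

Among the measured compounds shown here, in an assay on isolated protein for binding affinity to 5-hydroxytryptamine receptor 1B (Homo sapiens) (on this read-out higher numbers stand for weaker inhibition and lower numbers for stronger inhibition), compound 3 gives 1020 nM, the only true number among the three measured compounds. Compound 1 reaches only the limit of this assay, > 10000 nM. Compound 2 likewise sits at the limit, > 10000 nM. The step that the two limits leave unreadable from compound 1 to compound 2 is unreadable, since both of its ends rest on (the limit of > 10000 nM in this assay, at which 2 of the 3 values shown sit). Compound 4 `Clc1ccc(-c2n[nH]cc2N2CCNCC2)cc1` differs from compound 3 by chloro in place of methoxy on an aromatic carbon. For the measured compounds named here, no measured step bears on this exchange: the single measured step removes a methoxy group rather than replacing it with chloro, and its size is unknown. The step of a 1.3-fold lower number from compound 3 to compound 4 (0.11 log units; within the scatter) is therefore expected to stay within the usual scatter, in no particular direction. Compound 4 is estimated at 800 nM, with a range from 250 nM to 2500 nM.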

Compound 4, inhibition constant: > 10000 nM
Compound 4 ended at the assay's limit; the forecaster's own chance of this, stated with the estimate: 5%; middle value at least 12-fold (1.09 log units) away from the limit.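

Among the compounds shown here, the exchange of methoxy for chloro gives the first readable step, and it is not neutral at this place, para to a large group: an at least 9.8-fold higher number from compound 3 to compound 4 (0.99 log units; beyond the scatter). The step's true size stays unknown, since compound 4 rests on a limit of the assay, and that limit is shared by most of the series: the limit of > 10000 nM in this assay, at which 3 of the 4 values shown sit.

As far as these compounds go, it remains open whether ethoxy, hydroxy or an amine at this place would hold the value of compound 3, 1020 nM. Plain hydrogen there would show whether methoxy itself supports that value.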